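Replacing the Methylamide of Compound 1 with a Morpholine Amide

The source may report more compounds than this note shows. Statements on the series, on what has been measured and on what is new or still open speak of the compounds shown alone.

Compound 1 `CNC(=O)Cn1nc(N)c2c(C(F)(F)F)cc(-c3ccccc3)nc21`: 11800 nM
Compound 2 `NNC(=O)Cn1nc(N)c2c(C(F)(F)F)cc(-c3ccccc3)nc21`: 35400 nM

Within the data shown here, in a functional assay on MCF7 cells (Homo sapiens) for cytotoxicity, read by MTT assay, with a stated time of 24 h (on this read-out higher numbers stand for weaker inhibition and lower numbers for stronger inhibition), compound 1 stands lowest of the two numbers measured so far, with compound 2 as its only neighbour. Among the measured compounds shown here, the single measured step, a 3.0-fold higher number from compound 1 to compound 2 (0.48 log units; beyond the scatter), came from a change on the amide-type nitrogen and was modest. Compound 3 `Nc1nn(CC(=O)N2CCOCC2)c2nc(-c3ccccc3)cc(C(F)(F)F)c12` differs from compound 1 at the same carbonyl carbon: morpholin-4-yl in place of methylamino on a carbonyl carbon. For the measured compounds named here, because the one step in hand, a 3.0-fold higher number from compound 1 to compound 2 (0.48 log units; beyond the scatter), was beyond the scatter but small, and because it is the only precedent for varying this amide, the expectation for compound 3 is a step of similar or smaller size, more likely upward than downward, and possibly within the scatter. Compound 3 is therefore estimated at 16000 nM, between 6000 nM and 45000 nM, an expected step of a 1.4-fold higher number from compound 1 to compound 3 (0.13 log units; within the scatter).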

Compound 3, half-maximal inhibitory concentration: 5900 nM
Compound 3: the middle estimate sits 2.7-fold (0.43 log units) above what was measured; the measured number lies below the stated range.
By their numbers in this assay, from the lowest: compounds 3 and 1 (each within the scatter of the next); then compound 2.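

In this assay, the position on the carbonyl carbon tolerates a ring-bearing tertiary amide: exchanging methylamino for morpholin-4-yl removes the amide hydrogen and adds a six-membered ring, yet gives a 2.0-fold lower number from compound 1 to compound 3 (0.30 log units; within the scatter). The earlier pair could not show this, as it covered only a change on an amide nitrogen that kept its hydrogen, whereas the new comparison with the aminoamino compound gives a 6.0-fold lower number from compound 2 to compound 3 (0.78 log units; beyond the scatter), so among these compounds the aminoamino group alone stands apart. Nothing available explains these differences.

On these data alone, it remains open whether the ring oxygen of morpholin-4-yl matters, which a piperidin-1-yl amide would test, and whether an open-chain dimethylamino amide would read the same way. As far as these compounds go, how a carboxylic acid or a piperazin-1-yl amide at this carbonyl carbon would behave also remains unknown.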